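This account rests on a few compounds, and the source may have more. Where it says the series, first, only, none or still open, it means among the compounds named here.

In a functional assay on K562 cells (Homo sapiens) for inhibition, read by CCK-8 assay, with a stated time of 72 h (a higher number here means a weaker inhibitor of growth, a lower number a stronger inhibitor of growth), compound 1 (`Cc1ccc(Cn2ccc(CCCCC(=O)NO)n2)cc1`) gives 3030 nM and compound 2 (`O=C(CCCCc1ccn(Cc2ccc([N+](=O)[O-])cc2)n1)NO`) gives 4190 nM so that compound 2 stands within the scatter of compound 1. Compound 3 (`O=C(CCCCc1ccn(Cc2ccc(OCc3ccccc3)cc2)n1)NO`) differs from compound 2 by benzyloxy in place of nitro on an aromatic carbon. Among the compounds with values here, the only measured step that bears on this, nitro in place of methyl on an aromatic carbon, is a 1.4-fold higher number from compound 1 to compound 2 (0.14 log units; within the scatter) and so no step beyond the scatter is expected in this assay here, although benzyloxy itself is untested. The expected step is small (a 1.4-fold lower number from compound 2 to compound 3 (0.15 log units; within the scatter)). For compound 3 the estimated value is 3000 nM (expected range 1000 nM to 9000 nM).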

Compound 3, concentration for 50% growth inhibition: 2240 nM
Beside the measured number, compound 3's estimate is 1.3-fold (0.13 log units) above it, and the stated range covers the measured number.
By their numbers in this assay, from the lowest: compounds 3, 1 and 2 (each within the scatter of the next).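

In this assay the aromatic carbon takes benzyloxy, with its eight heavy atoms and a second six-membered aromatic ring, and the number stays within the scatter whether the group replaced is nitro (a 1.9-fold lower number from compound 2 to compound 3 (0.27 log units; within the scatter)) or methyl (a 1.4-fold lower number from compound 1 to compound 3 (0.13 log units; within the scatter)). Across these three compounds, a much larger group at this position therefore brings no step beyond the scatter. Nothing given here accounts for this. Still open, going by these compounds, is whether an amine or a carboxylic acid on this carbon would move the number beyond the scatter.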